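Cytotoxicity of a triazole series: a carbonyl substituent swap

The compounds below may be only part of what the source reports. "The series", "measured", "known", "first", "only" and "open" are said of these compounds alone.

Measured compounds:
compound 1 `COc1cc(-c2nnc(SCC(=O)c3ccc(C)cc3)n2N)cc(OC)c1OC` — in an ADME assay on HEK293 cells (Homo sapiens) for cytotoxicity, read by MTT assay, with a stated time of 48 h (on this read-out lower numbers stand for stronger inhibition and higher numbers for weaker inhibition), compound 1 gives 100000 nM
compound 2 `COc1cc(-c2nnc(SCC(=O)c3cccc(Br)c3)n2N)cc(OC)c1OC` — in this assay compound 2 gives "not determined" (no result reported)

Within the data shown here, compound 1 is the only compound here with a number. Its value in this assay lies at the high end of the scale, which on this read-out means weak inhibition of the cells. Compound 2 carries no number and so cannot be placed against it.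

Compound 3 `COc1cccc(NC(=O)CSc2nnc(-c3cc(OC)c(OC)c(OC)c3)n2N)c1` shares the core of compound 1 and differs from it in a single place: (3-methoxyphenyl)amino in place of 4-methylphenyl on a carbonyl carbon.

Among the measured compounds shown here, no pair of measured compounds shows what such a change does in this assay, so nothing here indicates a direction. Because compound 1 already gives 100000 nM, the step of no change at the digits printed from compound 1 to compound 3 (within the scatter) is expected to be none beyond the scatter. Compound 3 is accordingly estimated at 100000 nM in this assay, with a range from 50000 nM to 200000 nM.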

Compound 3, half-maximal inhibitory concentration: 100000 nM
For compound 3 middle estimate and measured number coincide at the digits printed; low and high end bracket the measured number.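

Among these compounds, putting (3-methoxyphenyl)amino in place of 4-methylphenyl on a carbonyl carbon gives the first readable step at this position in this assay: no change at the digits printed from compound 1 to compound 3 (within the scatter). The entering group has more heavy atoms than the leaving one and brings a hydrogen-bond donor and a hydrogen-bond acceptor where 4-methylphenyl has none, yet the values of the two compounds lie within the scatter of each other, so this one swap gives no sign of stronger or weaker inhibition of the cells. Nothing measured alongside these compounds accounts for the agreement of the two values.

Among the compounds shown here, with only this one step, it remains open whether the result extends to other aromatic amino groups on the same carbonyl carbon, such as (4-methoxyphenyl)amino, or to a non-aromatic amine such as morpholine. Also open, going by these compounds, is what a carboxylic acid or a longer saturated chain would give at this place, and whether any group there would yield a value clearly lower than that of compound 1.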